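Swapping fluorines for chlorines on the aryl ring

A few compounds are considered here, and "the series" means these few. Any claim that something is new, unique, unknown or untested is made for them only; others in the source may bear on it.

Of the compounds shown here, three have been measured in an assay on microsomes from intestine for inhibition of acyl-CoA:cholesterol acyltransferase (Oryctolagus cuniculus); on this read-out lower numbers stand for stronger inhibition and higher numbers for weaker inhibition. Compound 2, `CCCCCCCC/C=C\CCCCCCCC1=NN(c2ccc(F)cc2F)C(=O)C1`, gives 5000 nM. Compound 1, `CC(C)c1cccc(C(C)C)c1N1CNC(C(c2ccccc2)c2ccccc2)C1=O`, gives 3900 nM, and compound 3, `CC(C)c1cccc(C(C)C)c1N1CN(C(c2ccccc2)c2ccccc2)CC1=O`, gives 1300 nM. Among these three numbers, compound 2 stands highest; the gap to compound 1 is within the usual scatter, so no order between the two can be claimed, while compound 3 shows a lower number, beyond the scatter.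

Compound 4, `CCCCCCCC/C=C\CCCCCCCC1=NN(c2ccc(Cl)cc2Cl)C(=O)C1`, is the next compound to be measured in this assay. It differs from compound 2 in one place: 2,4-dichlorophenyl in place of 2,4-difluorophenyl on an amide-type nitrogen in a ring. Among the compounds with values here, no pair of measured compounds tests a halogen swap of this kind, so there is no measured step to lean on. The expected step, a 1.7-fold lower number from compound 2 to compound 4 (0.22 log units; within the scatter), is therefore a small one, towards a somewhat lower number, but not beyond the usual scatter. On that basis compound 4 is expected to give about 3000 nM, within a range from 1000 nM to 9000 nM.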

Compound 4, half-maximal inhibitory concentration: 9900 nM
Compound 4: middle estimate off by 3.3-fold (0.52 log units), on the low side; measured number above the stated range.
By their numbers in this assay, from the lowest: compound 3; then compounds 1, 2 and 4 (each within the scatter of the next, the first and the last beyond it).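

In this assay, putting 2,4-dichlorophenyl in place of 2,4-difluorophenyl on the amide-type nitrogen in the ring gives a 2.0-fold higher number from compound 2 to compound 4 (0.30 log units; within the scatter). Within the data shown here, this is the first measured step at this place in the molecule, and it shows that the two halogen pairs cannot be told apart here: no order can be claimed between compound 2 and compound 4. The data offer no independent measurement that could explain this result.

On these data alone, it remains open whether a plain phenyl ring with no halogen, or a 2,4-dimethoxyphenyl group, would also read like these two on the same nitrogen. Also open, as far as these compounds go, is what happens when the long unsaturated chain on this ring is replaced by a shorter chain, with the 2,4-dichlorophenyl group kept in place.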